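Changing the aryl on the sulfonamide nitrogen from compound 3 to compound 4

This account rests on a few compounds, and the source may have more. Where it says the series, first, only, none or still open, it means among the compounds named here.

Compound 1 `CCc1ccccc1N(CC(=O)NCc1ccc(OC)c(OC)c1)S(=O)(=O)c1ccc(C)cc1` is measured in an assay on CHO cells for displacement of a labelled ligand from prostaglandin E2 receptor EP1 subtype (Homo sapiens) (a lower number here means a stronger inhibitor, a higher number a weaker inhibitor), where compound 1 gives 25.1 nM. Among the compounds with values here, compound 2 `CCc1ccccc1N(CC(=O)NCc1cccc(OC)c1)S(=O)(=O)c1ccc(C)cc1` differs by hydrogen in place of methoxy on an aromatic carbon; in this assay compound 2 gives 79.4 nM, and the step of a 3.2-fold higher number from compound 1 to compound 2 (0.50 log units; beyond the scatter) is the only measured change in this set. Compound 3 `Cc1ccc(S(=O)(=O)N(CC(=O)NCc2ccc(Cl)cc2)c2cccnc2)cc1` carries a different group on the sulfonamide nitrogen and a different amide substituent. In this assay compound 3 gives only < 1000 nM, which is a limit of the assay and not a number, as recorded in the limit of < 1000 nM in this assay, at which 1 of the 3 values shown sits. Compound 4 `Cc1ccc(S(=O)(=O)N(CC(=O)NCc2ccc(Cl)cc2)c2cccc(C)n2)cc1` follows from compound 3 by 6-methylpyridin-2-yl in place of pyridin-3-yl on a sulfonamide nitrogen. Within the data shown here, no measured step touches the group on the sulfonamide nitrogen, so the single measured step gives no guide to the size or direction of this change, and compound 3 itself supplies only a limit to start from. The expectation rests instead on the range in which compounds 1 and 2 fall. What is expected here is therefore a step that the limit leaves unreadable from compound 3 to compound 4. For compound 4 in this assay the expected value is 150 nM, within a range from 30 nM to 800 nM.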

Compound 4, inhibition constant: < 1000 nM
Compound 4: a limit, no number (the forecaster's own chance of this, stated with the estimate: 20%); the middle value lies beyond the limit too.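

Compound 3 and compound 4 each give a limit of the assay and not a number in this assay, so no step can be read between them: the limit of < 1000 nM in this assay, at which 2 of the 4 values shown sit.

The compounds shown leave open how pyridin-3-yl and 6-methylpyridin-2-yl on a sulfonamide nitrogen compare in this assay.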